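The source may hold more compounds than are shown below. What is called first, only, known or untested is meant among the compounds shown, and "the series" means these compounds.

Four close relatives of one sulfonate ester were compared for their ability to slow the growth of a human melanoma cell line, in a functional assay on M21 cells (Homo sapiens) for antiproliferative activity, read by sulforhodamine B assay, with a stated time of 48 h; a higher number here means a weaker inhibitor, a lower number a stronger inhibitor. Compound 1, `CC(C)c1ccccc1OS(=O)(=O)c1ccc(NC(=O)CCCl)cc1`, gives 14000 nM in this assay. Compound 2, `O=C(CCCl)Nc1ccc(S(=O)(=O)Oc2ccccc2I)cc1`, differs from compound 1 only by iodo in place of isopropyl on an aromatic carbon, and in this assay compound 2 gives 12000 nM, a change of a 1.2-fold lower number from compound 1 to compound 2 (0.07 log units; within the scatter). Compound 3, `CC(C)c1ccccc1OS(=O)(=O)c1ccc(NC(=O)NCCCCl)cc1`, carries the same two-ring core as compound 1 but differs at the amide end by (3-chloropropyl)amino in place of 2-chloroethyl on a carbonyl carbon; in this assay compound 3 gives 9300 nM, which is a 1.5-fold lower number from compound 1 to compound 3 (0.18 log units; within the scatter). All three numbers sit close together, and none of the steps between them goes beyond what repeated measurements normally show.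

Compound 4, `O=C(NCCCCl)Nc1ccc(S(=O)(=O)Oc2ccccc2I)cc1`, has not yet been measured. It stands to compound 3 as compound 2 stands to compound 1: the difference is iodo in place of isopropyl on an aromatic carbon, and the surroundings of the changed position are described in the same words in both pairs, so this is the same change made on the urea-containing core rather than on the amide-containing one. Because the earlier instance of this change produced only a 1.2-fold lower number from compound 1 to compound 2 (0.07 log units; within the scatter), the step from compound 3 to compound 4 is expected to be similarly small, about a 1.2-fold lower number from compound 3 to compound 4 (0.08 log units; within the scatter). On that basis compound 4 is estimated to give roughly 7800 nM in this assay, most likely between 4000 nM and 15000 nM.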

Compound 4, half-maximal inhibitory concentration: 4600 nM
Compound 4: the middle estimate sits 1.7-fold (0.23 log units) above what was measured; the measured number falls inside the stated range.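

In this assay, iodo in place of isopropyl on an aromatic carbon gives a 2.0-fold lower number from compound 3 to compound 4 (0.31 log units; beyond the scatter) and this modest step is the larger of the two seen for this change, but the two instances do not truly differ: the same change on two cores in this assay, a 1.2-fold lower number (0.07 log units; within the scatter) from compound 1 to compound 2 and a 2.0-fold lower number (0.31 log units; beyond the scatter) from compound 3 to compound 4, 1.7-fold (0.24 log units) apart, within the scatter of two such steps.

The other change, (3-chloropropyl)amino in place of 2-chloroethyl on a carbonyl carbon, gives a 2.6-fold lower number from compound 2 to compound 4 (0.42 log units; beyond the scatter) and it also agrees with its earlier instance: the same change on two cores in this assay, a 1.5-fold lower number (0.18 log units; within the scatter) from compound 1 to compound 3 and a 2.6-fold lower number (0.42 log units; beyond the scatter) from compound 2 to compound 4, 1.7-fold (0.24 log units) apart, within the scatter of two such steps.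

Within the data shown here, these comparisons show that each change had a similar size on both cores, so neither change gives a detectable sign of depending on the core it is made on, but with only one pair of steps per change they cannot prove that the two changes are fully independent, and they do not explain why either step has the size it has.

The compounds shown leave open how a bromo or a methyl group would compare with iodo and isopropyl at the same place on the ring. They also leave open whether a longer chain, or a chain ending in an amine instead of chlorine, would follow the same pattern.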